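A few compounds are considered here, and "the series" means these few. Any claim that something is new, unique, unknown or untested is made for them only; others in the source may bear on it.

Three compounds have been measured in a functional assay on the whole organism (strain Wistar) for inhibition, with Rattus norvegicus as the target, read by paw edema, with a stated time of 24 h, at a dose of 100 mg/kg; on this read-out lower numbers stand for less inhibition and higher numbers for more inhibition at the one dose given (going by the name of the read-out):

Compound 1 `COc1cc2c(cc1OC)C(CC(=O)Nc1ccccc1)CC2` gives 30%.
Compound 2 `COc1cc2c(cc1OC)C(CC(=O)Nc1cccc(Cl)c1)CC2` gives 63.3%.
Compound 3 `COc1cc2c(cc1OC)C(CC(=O)Nc1ccc(Cl)cc1)CC2` gives 70%.

Compound 3 has the highest of the three numbers, but the gap a number 6.7 percentage points higher from compound 2 to compound 3 (within the scatter) is within the scatter, while the gap a number 40 percentage points higher from compound 1 to compound 3 (beyond the scatter) is large. Compound 4 `COc1cc2c(cc1OC)C(CC(=O)Nc1ccc(Br)cc1)CC2` differs from compound 3 in one place: bromo in place of chloro on an aromatic carbon.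

The measured steps that bear on this change are those that put a halogen onto the phenyl ring: a number 33.3 percentage points higher from compound 1 to compound 2 (beyond the scatter) and a number 40 percentage points higher from compound 1 to compound 3 (beyond the scatter), both large. The step of a number 6.7 percentage points higher from compound 2 to compound 3 (within the scatter), which moves the chloro between two positions, stays within the scatter. For the measured compounds named here, no measured step swaps one halogen for another, so the expectation rests on the halogen-bearing compounds 2 and 3 alone. Compound 4 keeps a halogen at the same place as compound 3, so the step is expected to stay within the scatter, no change at the digits printed from compound 3 to compound 4 (within the scatter). Compound 4 is therefore estimated to give 70%, with a range from 55% to 85%.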

Compound 4, a percentage reported as inhibition, in the whole organism at one dose (the size of the read-out at that dose, not a potency): 66.7%
Compound 4: middle estimate off by 3.3 percentage points, on the high side; low and high end bracket the measured number.
By their numbers in this assay, from the lowest: compound 1; then compounds 2, 4 and 3 (each within the scatter of the next).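

In this assay, for the compounds shown here, this is the first exchange of one halogen for another on the aromatic carbon para to a large group, and bromo in place of chloro gives a number 3.3 percentage points lower from compound 3 to compound 4 (within the scatter) with no change that can be told from the scatter. Bromo in place of hydrogen gives a number 36.7 percentage points higher from compound 1 to compound 4 (beyond the scatter) as a large step, so the large step seen with chloro at this place also appears with this second halogen. The step of a number 3.4 percentage points higher from compound 2 to compound 4 (within the scatter) also stays within the scatter, so compound 2 and compound 4 cannot be told apart here, even though they differ in both the halogen and its place on the ring.

As far as these compounds go, whether fluoro, a methyl group or an amine at this place would also give a large step remains open. No measurement shown here explains why these halogen-bearing compounds give higher numbers than compound 1.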